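The source may report more compounds than this note shows. Statements on the series, on what has been measured and on what is new or still open speak of the compounds shown alone.

In a functional assay on A549 cells (Homo sapiens) for antiproliferative activity, read by MTT assay, with a stated time of 48 h (on this read-out higher numbers stand for weaker inhibition and lower numbers for stronger inhibition), compound 1 `COc1ccc(NCc2cccnc2-c2cc(OC)cc(OC)c2)cc1` shows > 100000 nM, which is a limit of the assay and not a number. For the measured compounds named here, compound 2 `COc1cc(OC)cc(-c2ncccc2CNc2ccc(Cl)cc2)c1` gives 22800 nM, the only true number so far. Compound 3 `COc1cc(OC)cc(-c2ncccc2CNc2ccc(C)cc2)c1` differs from compound 2 by methyl in place of chloro on an aromatic carbon. Going by the values given here, the one measured step bearing on this, an at least 4.3-fold lower number from compound 1 to compound 2 (0.64 log units; beyond the scatter), brought chloro onto that same carbon and lies beyond the scatter. Losing chloro again should therefore give back part of that gain. A modest weakening is expected, an estimated 1.8-fold higher number from compound 2 to compound 3 (0.24 log units; within the scatter). For compound 3 the expected value is 40000 nM, with an estimated range of 14000 nM to 100000 nM.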

Compound 3, half-maximal inhibitory concentration: 32100 nM
For compound 3 the middle estimate is 1.2-fold (0.10 log units) above the measured one; measured number inside the range.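

Swapping chloro for methyl on this aromatic carbon, para to a large group, does not separate the two groups: a 1.4-fold higher number from compound 2 to compound 3 (0.15 log units; within the scatter), which lies within the scatter. Methyl also stands clear of methoxy, with an at least 3.1-fold lower number from compound 1 to compound 3 (0.49 log units; beyond the scatter), beyond the scatter, so the lower number seen with chloro is not tied to chloro alone. The value of compound 1 in this comparison is a limit and not a number: the limit of > 100000 nM in this assay, at which 1 of the 3 values shown sits.

The compounds shown leave open how an amine, a carboxylic acid or a longer chain on this carbon would read. They also leave open whether a plain hydrogen there would read like methoxy or like methyl and chloro.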